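Working notes: aryl replacement on an aromatic nitrogen

The source may report more compounds than this note shows. Statements on the series, on what has been measured and on what is new or still open speak of the compounds shown alone.

Measured so far:
Compound 1, `Cc1cccc(-n2nncc2CN2C(=O)C3(C(C#N)=C(N)Oc4c3c3nc5ccccc5nc3c3ccccc43)c3ccccc32)c1`, in a functional assay on HepG2 cells (Homo sapiens) for antiproliferative activity, read by MTT assay, with a stated time of 48 h (on this read-out higher numbers stand for weaker inhibition and lower numbers for stronger inhibition), gives > 50000 nM, a limit of the assay and not a number.
Compound 2, `COc1ccccc1-n1nncc1CN1C(=O)C2(C(C#N)=C(N)Oc3c2c2nc4ccccc4nc2c2ccccc32)c2ccccc21`, in this assay gives > 50000 nM, again a limit.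
Compound 3, `CCOc1ccc(-n2nncc2CN2C(=O)C3(C(C#N)=C(N)Oc4c3c3nc5ccccc5nc3c3ccccc43)c3ccccc32)cc1`, in this assay gives > 50000 nM, also a limit.

Compound 3 therefore stands at the limit, and so do the two other measured compounds: the limit of > 50000 nM in this assay, at which 3 of the 3 values shown sit. The three pairwise steps, a step that the two limits leave unreadable from compound 1 to compound 2, a step that the two limits leave unreadable from compound 1 to compound 3 and a step that the two limits leave unreadable from compound 2 to compound 3, are unreadable for the same reason; the aryl groups on the aromatic nitrogen so far give no readable size or direction in this assay.

Compound 4, `N#CC1=C(N)Oc2c(c3nc4ccccc4nc3c3ccccc23)C12C(=O)N(Cc1cnnn1-c1ccc(N)cc1)c1ccccc12`, carries the change (amino in place of ethoxy on an aromatic carbon). Among the measured compounds shown here, no measured step bears on this change, since every step so far is hidden by the limit. With nothing in the measured set pointing to inhibition within range, compound 4 is expected to remain at the limit, and the step that the limit leaves unreadable from compound 3 to compound 4 is expected to be no more than a guess. The estimate for compound 4 in this assay is 80000 nM, within 20000 nM to 400000 nM.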

Compound 4, half-maximal inhibitory concentration: > 50000 nM
Compound 4 was reported as a limit (the forecaster's own chance of this, stated with the estimate: 80%); the middle value is on the limit's open side.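

In this assay compound 4 gives > 50000 nM, a limit of the assay and not a number. Its steps from compound 1, compound 2 and compound 3 cannot be read, and all four compounds sit at the same limit: the limit of > 50000 nM in this assay, at which 4 of the 4 values shown sit.

The compounds shown leave open whether any aryl group on the aromatic nitrogen gives a measurable value on this shared core.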